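A few compounds are considered here, and "the series" means these few. Any claim that something is new, unique, unknown or untested is made for them only; others in the source may bear on it.

Measured compounds:
- compound 1, `Nc1ccccc1NC(=O)c1ccc(Cn2cnc3c(NCc4ccccc4)nc(Cl)nc32)cc1`: 44.7% in a functional assay on NCI-H460 cells (Homo sapiens) for antiproliferative activity, read by CCK-8 assay, with a stated time of 72 h, tested at 2 uM; a higher number here means a stronger effect of the compound at the concentration tested, a lower number a weaker effect
- compound 2, `Nc1ccccc1NC(=O)/C=C/c1ccc(COCNc2nc(Nc3cccc(Cl)c3)c3ncn(C4CCCC4)c3n2)cc1`: 37.1% in this assay
- compound 3, `CC(C)n1cnc2c(Nc3cccc(Cl)c3)nc(NCOCc3ccc(/C=C/C(=O)Nc4ccccc4N)cc3)nc21`: 53% in this assay

Compound 1 stands close to both other compounds: its gap to compound 2 and its gap to compound 3 each lie within the usual scatter of repeated measurements, so none of the three can be called stronger or weaker than another on these numbers alone. Among the measured compounds shown here, the one step between two compounds that differ in a single place is a number 15.9 percentage points higher from compound 2 to compound 3 (beyond the scatter), an exchange of isopropyl for cyclopentyl on an aromatic nitrogen of the shared core.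

Compound 4, `Nc1ccccc1NC(=O)c1ccc(Cn2cnc3c(Nc4cccc(OC(F)(F)F)c4)nc(Cl)nc32)cc1`, has not yet been measured in this assay. It differs from compound 1 in one place: 3-(trifluoromethoxy)phenyl in place of benzyl on a nitrogen on an aromatic ring. For the measured compounds named here, no measured step touches this nitrogen or these groups; the only measured step concerns a different aromatic nitrogen, so it gives no guide to direction or size here. With nothing pointing either way, the expected step is a number 2.3 percentage points higher from compound 1 to compound 4 (within the scatter), that is, no step beyond the scatter, but with wide uncertainty. Compound 4 is therefore estimated at 47%, with a range from 28% to 66%.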

Compound 4, a percentage reported as inhibition, at one concentration (the size of the read-out at that concentration, not a potency): 47.7%
Compound 4: middle estimate off by 0.7 percentage points, on the low side, within the range that was stated.
By their numbers in this assay, from the lowest: compounds 2, 1, 4 and 3 (each within the scatter of the next, the first and the last beyond it).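

Among the compounds shown here, the exchange of benzyl for 3-(trifluoromethoxy)phenyl on a nitrogen on an aromatic ring gives a number 3 percentage points higher from compound 1 to compound 4 (within the scatter) in this assay, the first measured step at this position, and on these numbers compound 1 and compound 4 cannot be told apart. At this position on this core, then, a group of 11 heavy atoms with one hydrogen-bond acceptor takes the place of a group of 7 heavy atoms with none, and the read-out does not separate the two. No measurement of any property of these groups comes with the result, so the finding remains a comparison of two numbers.

On these data alone, only these two groups have been seen on this nitrogen, so it remains open whether a group without an aromatic ring, such as a longer alkyl chain or a morpholine ring, would also leave the read-out within the scatter or would move it beyond. As far as these compounds go, each compound was also read at a single concentration, so a potency difference between compound 1 and compound 4 at other concentrations remains open too.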